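The compounds below may be only part of what the source reports. "The series", "measured", "known", "first", "only" and "open" are said of these compounds alone.

In a functional assay on B16 cells (Mus musculus) for cytotoxicity, read by CCK-8 assay, with a stated time of 24 h (on this read-out higher numbers stand for weaker inhibition and lower numbers for stronger inhibition), compound 3 `COc1ccccc1Oc1c(N)nc(-c2cccc(C)c2)nc1OCCO` gives 70900 nM, a higher number than compound 1 `COc1ccccc1Oc1c(N)nc(-c2ccccc2)nc1OCCO` at 31100 nM and within the scatter of compound 2 `COc1ccccc1Oc1c(N)nc(Cc2ccccc2)nc1OCCO` at 47400 nM. Compound 4 `COc1ccccc1Oc1c(N)nc(-c2ccccc2F)nc1OCCO` carries 2-fluorophenyl in place of 3-methylphenyl on an aromatic carbon. Among the measured compounds shown here, two measured steps bear on this. The methyl step, a 2.3-fold higher number from compound 1 to compound 3 (0.36 log units; beyond the scatter), is modest, while the benzyl change, a 1.5-fold higher number from compound 1 to compound 2 (0.18 log units; within the scatter), stays small. For the measured compounds named here, no fluorinated compound has been measured, so only the loss of the methyl group has any guide. A modest move towards a lower number is expected, with a 2.3-fold higher number from compound 1 to compound 3 (0.36 log units; beyond the scatter) step partly reversed. The expected step is a 1.7-fold lower number from compound 3 to compound 4 (0.23 log units; within the scatter). For compound 4 the estimated value is 42000 nM, with an expected range of 18000 nM to 90000 nM.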

Compound 4, half-maximal inhibitory concentration: 11800 nM
For compound 4 the middle estimate is 3.6-fold (0.55 log units) above the measured one, outside the stated range (below it).
By their numbers in this assay, from the lowest: compound 4; then compounds 1, 2 and 3 (each within the scatter of the next, the first and the last beyond it).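

In this assay, the aromatic carbon between two ring nitrogen atoms tolerates a change that lowers the number: fluoro in place of hydrogen gives a 2.6-fold lower number from compound 1 to compound 4 (0.42 log units; beyond the scatter), whereas methyl had raised it. The 2-fluorophenyl group also gives a 6.0-fold lower number from compound 3 to compound 4 (0.78 log units; beyond the scatter) and a 4.0-fold lower number from compound 2 to compound 4 (0.60 log units; beyond the scatter), leaving compound 4 as the most potent of the four. Nothing available explains these steps. From the compounds shown here alone, whether chloro or a nitrile in place of fluoro would lower the number likewise remains open. So does whether the fluoro step survives a longer chain in place of the 2-hydroxyethoxy group.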